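The source may hold more compounds than are shown below. What is called first, only, known or untested is meant among the compounds shown, and "the series" means these compounds.

Compound 1, `C[C@@H](NC(=O)c1ccc(C#Cc2cccnc2)cn1)C(C)(C)O`: 71.5%
Compound 2, `C[C@@H](NC(=O)c1ccc(C#Cc2ccncc2)cn1)C(C)(C)O`: 66.6%

In a functional assay on HEK293 cells for positive allosteric modulation of metabotropic glutamate receptor 5 (Rattus norvegicus), read by fluorescence and calcium flux (on this read-out higher numbers stand for larger maximal responses and lower numbers for smaller maximal responses), compound 1 reaches 71.5% and compound 2 reaches 66.6%. For the measured compounds named here, the one measured step, a number 4.9 percentage points lower from compound 1 to compound 2 (within the scatter), goes with pyridin-4-yl in place of pyridin-3-yl on a triple-bonded carbon. Compound 2 thus stands as one of two numbers that lie within the scatter of each other; its nearest neighbour is compound 1, and the two cannot be told apart on this read-out.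

The next compound, compound 3, `CC1(NC(=O)c2ccc(C#Cc3ccncc3)cn2)COC1`, differs from compound 2 at the other end of the molecule: 3-methyloxetan-3-yl in place of 2-hydroxy-1,2-dimethylpropyl on an amide-type nitrogen. Going by the values given here, no measured step touches the amide-type nitrogen; the only step on record alters the group on the triple-bonded carbon and was within the scatter, so it gives no guidance on the present change. With nothing to lean on, the expected step of a number 4.6 percentage points lower from compound 2 to compound 3 (within the scatter) is taken as none beyond the scatter, and the range is kept wide. Compound 3 is therefore estimated at 62%, between 35% and 88%.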

Compound 3, largest response reached (reported as efficacy), in percent of the reference or control that the assay uses: 36%
Compound 3: the middle estimate sits 26 percentage points above what was measured; low and high end bracket the measured number.
By their numbers in this assay, from the lowest: compound 3; then compounds 2 and 1 (each within the scatter of the next).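

In this assay, for the compounds shown here, the group on the amide-type nitrogen proves to matter: a number 30.6 percentage points lower from compound 2 to compound 3 (beyond the scatter) follows when 3-methyloxetan-3-yl replaces 2-hydroxy-1,2-dimethylpropyl, whereas the only earlier step, at the triple-bonded carbon, was a number 4.9 percentage points lower from compound 1 to compound 2 (within the scatter) and gave no sign that any position could shift the maximal response this far. The change alters several things at once, since an open chain with 1 hydrogen-bond donor and 1 defined stereocentre gives way to a four-membered non-aromatic ring with 0 hydrogen-bond donors and no defined stereocentre, so this single step cannot assign the effect to any one of these differences. No measurement shown here explains the size of this step.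

The compounds shown leave open whether the lower response goes with the ring itself or with the loss of the hydroxyl-bearing chain, a question that a tert-butyl or a cyclobutyl group on the same nitrogen could help to separate. They also leave open whether 3-methyloxetan-3-yl would have a similar effect with pyridin-3-yl on the triple-bonded carbon, as in compound 1.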